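A few compounds are considered here, and "the series" means these few. Any claim that something is new, unique, unknown or untested is made for them only; others in the source may bear on it.

Series notes. Compound 1 `Cc1cc2[nH]nc(N)c2c(=O)[nH]1` gives 27% in an assay on isolated protein for inhibition of serine/threonine-protein kinase Chk2 (Homo sapiens), read by mobility shift assay, tested at 30 uM; on this read-out higher numbers stand for more inhibition at the one concentration tested (going by the name of the read-out) and lower numbers for less inhibition. Compound 2 `Cc1cc2c(c(N)nn2C)c(=O)[nH]1` gives 3% in this assay, and compound 3 `Cc1cc2c(cn1)c(N)nn2C` gives 3%. The difference between the cores of compound 2 and compound 3 is not broken down here; the two values stand level at the digits shown. Among the compounds with values here, the one counted step measured so far is a number 24 percentage points higher from compound 2 to compound 1 (beyond the scatter), the change being (hydrogen in place of methyl on an aromatic nitrogen). Compound 4 `Cc1cc2[nH]nc(N)c2cn1` is not yet measured; it differs from compound 3 by hydrogen in place of methyl on an aromatic nitrogen, the same change at the same place. The step expected from compound 3 to compound 4 is a number 17 percentage points higher from compound 3 to compound 4 (beyond the scatter), resting on compound 2 to compound 1 showing a number 24 percentage points higher from compound 2 to compound 1 (beyond the scatter), with some allowance for the cores of compound 2 and compound 3 being different. Compound 4 is therefore estimated at 20%, with the likely span 5% to 40%.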

Compound 4, a percentage reported as inhibition, at one concentration (the size of the read-out at that concentration, not a potency): 7%
Beside the measured number, compound 4's estimate is 13 percentage points above it; the range from low to high includes it.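

On the core of compound 3, hydrogen in place of methyl on an aromatic nitrogen gives a number 4 percentage points higher from compound 3 to compound 4 (within the scatter), so the gain seen on the core of compound 1 does not carry over at the same size. The size of this change depends on the core in this assay: the same change on two cores in this assay, a number 24 percentage points higher (beyond the scatter) from compound 2 to compound 1 and a number 4 percentage points higher (within the scatter) from compound 3 to compound 4, 20 percentage points apart, beyond the scatter of two such steps. This rests on one pair per core; it does not show which feature of the cores goes with the gap, or how the change would read on any further core.

As far as these compounds go, all four compounds carry the amino group, so how a longer chain or a carboxylic acid in its place would read in this assay stays open. Also open, from the compounds shown here alone, is whether either result extends to a larger group on that aromatic nitrogen, such as ethyl.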